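This account rests on a few compounds, and the source may have more. Where it says the series, first, only, none or still open, it means among the compounds named here.

Compound 1 `COc1cc2nc(Cl)nc(NS(=O)(=O)c3cccc(C(F)(F)F)c3)c2cc1OC`: 36.4 ug/mL
Compound 2 `COc1ccc(S(=O)(=O)Nc2nc(Cl)nc3cc(OC)c(OC)cc23)cc1C`: 79 ug/mL
Compound 3 `COc1cc2nc(Cl)nc(NS(=O)(=O)c3cccc4ccccc34)c2cc1OC`: 82.4 ug/mL

In a functional assay on THP-1 cells (Homo sapiens) for cytotoxicity, read by MTT assay, with a stated time of 24 h (on this read-out lower numbers stand for stronger inhibition and higher numbers for weaker inhibition), compound 2 gives the second highest of the three numbers. Compound 3 sits nearest to it, within the usual scatter, while compound 1 gives a lower number, a gap that lies beyond the scatter. Compound 4 `COc1cc2nc(Cl)nc(NS(=O)(=O)Cc3cccc(I)c3)c2cc1OC` has not yet been measured. It differs from compound 2 in one place: 3-iodobenzyl in place of 4-methoxy-3-methylphenyl on a sulfonyl sulfur. Within the data shown here, no measured pair shows a change of this kind, so the three numbers offer no guidance on direction. The expectation is for no step beyond the scatter, the estimated step being a 1.3-fold lower number from compound 2 to compound 4 (0.12 log units; within the scatter). Compound 4 is estimated at 60 ug/mL, within a range from 25 ug/mL to 150 ug/mL.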

Compound 4, half-maximal inhibitory concentration: 96.2 ug/mL
Beside the measured number, compound 4's estimate is 1.6-fold (0.21 log units) below it, and the stated range covers the measured number.
By their numbers in this assay, from the lowest: compound 1; then compounds 2, 3 and 4 (each within the scatter of the next).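

Among these compounds, replacing 4-methoxy-3-methylphenyl with 3-iodobenzyl on a sulfonyl sulfur gives a 1.2-fold higher number from compound 2 to compound 4 (0.09 log units; within the scatter) in this assay, the first comparison at this position in which only one place differs. This position therefore accepts both groups without a step beyond the scatter, although the entering group brings iodine and lacks the hydrogen-bond acceptor of the group that leaves. Nothing measured here offers an explanation for this result. As far as these compounds go, whether an amine or a carboxylic acid in this place would give a step beyond the scatter remains open.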